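Replacing 3-methoxyphenoxy with pentan-3-yl on the shared core

The compounds below may be only part of what the source reports. "The series", "measured", "known", "first", "only" and "open" are said of these compounds alone.

In an ADME assay for permeability, using PAMPA, with a stated time of 30 min, at pH 7.4 (on this read-out lower numbers stand for lower permeability and higher numbers for higher permeability), compound 1 `COc1ccc(F)cc1CNCCCNc1ccnc2cc(C3CCCCC3)ccc12` gives 23 10^-6 cm/s while compound 2 `COc1ccc(F)cc1CNCCCNc1ccnc2cc(Oc3ccc(F)cc3)ccc12` gives 317 10^-6 cm/s and compound 3 `COc1cccc(Oc2ccc3c(NCCCNCc4cc(F)ccc4OC)ccnc3c2)c1` gives 317 10^-6 cm/s in the same series. Compound 3 thus stands level with compound 2, and together they hold the highest of the three numbers.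

The next structure is compound 4 `CCC(CC)c1ccc2c(NCCCNCc3cc(F)ccc3OC)ccnc2c1`, which differs from compound 3 in one place: pentan-3-yl in place of 3-methoxyphenoxy on an aromatic carbon with pentan-3-yl in place of 3-methoxyphenoxy on an aromatic carbon. Among the compounds with values here, no measured step makes this exact change. The nearest evidence is the large step of a 14-fold higher number from compound 1 to compound 3 (1.14 log units; beyond the scatter) on placing 3-methoxyphenoxy where cyclohexyl stood, matched by the equally large step a 14-fold higher number from compound 1 to compound 2 (1.14 log units; beyond the scatter) with 4-fluorophenoxy. Exchanging one phenoxy group for the other gave no change at the digits printed from compound 2 to compound 3 (within the scatter) and stayed within the scatter.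

Compound 4 gives up the phenoxy link and, like compound 1 at 23 10^-6 cm/s in this assay, carries a group of carbon only at that position. Within the data shown here, a large fall is therefore expected, although pentan-3-yl has no ring and no compound bearing it has been measured. The expected change is a 7.0-fold lower number from compound 3 to compound 4 (0.85 log units; beyond the scatter) by this estimate. For compound 4 the estimated value is 45 10^-6 cm/s with an expected range from 12 10^-6 cm/s to 200 10^-6 cm/s in this read-out.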

Compound 4, apparent permeability: 23 10^-6 cm/s
The estimate for compound 4 lay 2.0-fold (0.29 log units) above the measured number; the range from low to high includes it.
By their numbers in this assay, from the lowest: compounds 1 and 4 (each within the scatter of the next); then compounds 2 and 3 (each within the scatter of the next).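

In this assay, pentan-3-yl on this aromatic carbon gives a 14-fold lower number from compound 3 to compound 4 (1.14 log units; beyond the scatter) and, set against the other phenoxy group, a 14-fold lower number from compound 2 to compound 4 (1.14 log units; beyond the scatter) as well, so the large gap now appears on leaving either phenoxy group and no longer rests on cyclohexyl alone. Pentan-3-yl in place of cyclohexyl gives no change at the digits printed from compound 1 to compound 4 (within the scatter) and thus shows that, at this position, the saturated ring of cyclohexyl and the open carbon group without a ring cannot be told apart on this read-out. All four compounds now fall into two pairs with no exception: the two groups of carbon only, compounds 1 and 4, sit together, and the two phenoxy groups, compounds 2 and 3, sit together at the higher numbers.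

Whether the gap follows the oxygen link or the aromatic ring of the phenoxy groups stays open, and a phenyl group joined directly to this carbon, or a methoxy group there, would separate the two, while nothing available here gives a measured reason for the split between the pairs.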